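Bromo for methyl: cytotoxicity notes toward compound 3

This account rests on a few compounds, and the source may have more. Where it says the series, first, only, none or still open, it means among the compounds named here.

Compound 1, `Cc1ccc(-c2csc(N3N=C(c4ccc(C)s4)CC3c3ccc(F)cc3)n2)cc1`, has been run in an ADME assay on NIH3T3 cells (Mus musculus) for cytotoxicity, read by XTT assay, with a stated time of 24 h (on this read-out higher numbers stand for weaker inhibition and lower numbers for stronger inhibition), and the value returned for compound 1 is a limit of the assay, > 500 ug/mL. Among the measured compounds shown here, compound 2, `Fc1ccc(C2CC(c3ccc(Cl)s3)=NN2c2nc(-c3ccc(C(F)(F)F)cc3)cs2)cc1`, is the only other compound with a reading in this assay, and for compound 2 the value is likewise a limit, > 500 ug/mL. Both readings therefore sit at the same point, (the limit of > 500 ug/mL in this assay, at which 2 of the 2 values shown sit), so compound 1 cannot be ranked against compound 2 on these numbers; neither shows measurable cytotoxicity on this read-out.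

Compound 3, `Cc1ccc(C2=NN(c3nc(-c4ccc(Br)cc4)cs3)C(c3ccc(F)cc3)C2)s1`, is not yet measured. Relative to compound 1 it carries bromo in place of methyl on an aromatic carbon, that is bromo in place of methyl on an aromatic carbon. For the measured compounds named here, no step between measured compounds covers this change, so no measured size can be assigned to it. Because compound 1 sits at the limit of > 500 ug/mL in this assay, at which 2 of the 2 values shown sit, the step of a number no higher from compound 1 to compound 3 (the limit leaves the size open) is expected to be none beyond the scatter, and the result for compound 3 is expected to be another limit rather than a number. The estimate for compound 3 is 500 ug/mL, with a range from 250 ug/mL to 1000 ug/mL.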

Compound 3, half-maximal inhibitory concentration: > 500 ug/mL
Compound 3: only a limit was reported; the forecaster's own chance of this, stated with the estimate: 85%; the middle value lies on the limit itself.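

In this assay compound 3 gives a limit of the assay, > 500 ug/mL. No step can be read between compound 1 and compound 3, since both readings are limits: the limit of > 500 ug/mL in this assay, at which 3 of the 3 values shown sit.

The compounds shown leave open whether bromo in place of methyl on the aromatic carbon changes cytotoxicity at all, and in which direction.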